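The compounds below may be only part of what the source reports. "The series", "measured", "known", "first", "only" and "open" are said of these compounds alone.

Among the measured compounds shown here, compound 1 `Cc1ccc(C(=O)Nc2cccc(-c3oc4cc(-c5ccc(F)cc5)ccc4c(=O)c3O)c2)cc1` is one of two compounds measured in a functional assay on HeLa cells (Homo sapiens) for antiproliferative activity, read by CCK-8 assay, with a stated time of 72 h; on this read-out higher numbers stand for weaker inhibition and lower numbers for stronger inhibition; compound 1 gives 6190 nM, the higher of the two numbers, though its gap to the only neighbour lies within the scatter. For the measured compounds named here, that neighbour is compound 2 `O=C(Nc1cccc(-c2oc3cc(-c4ccc(F)cc4)ccc3c(=O)c2O)c1)c1ccc(Cl)cc1`, which in this assay gives 3670 nM; the step of a 1.7-fold lower number from compound 1 to compound 2 (0.23 log units; within the scatter) is the sole measured step here. Compound 3 `O=C(Nc1cccc(-c2oc3cc(-c4ccc(F)cc4)ccc3c(=O)c2O)c1)c1ccc(Cl)nc1` differs from compound 1 by 6-chloropyridin-3-yl in place of 4-methylphenyl on a carbonyl carbon. Going by the values given here, the change carries the same chloro-for-methyl exchange seen from compound 1 to compound 2, together with an added ring nitrogen whose effect no measured pair addresses. Among the compounds with values here, since the only relevant step, a 1.7-fold lower number from compound 1 to compound 2 (0.23 log units; within the scatter), stayed within the scatter, the expected step of a 1.8-fold lower number from compound 1 to compound 3 (0.25 log units; within the scatter) is a modest lowering of the number at most, possibly none beyond the scatter. Compound 3 is therefore estimated at 3500 nM, with a likely range from 1200 nM to 9500 nM.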

Compound 3, half-maximal inhibitory concentration: 4080 nM
Compound 3: middle estimate off by 1.2-fold (0.07 log units), on the low side, within the range that was stated.
By their numbers in this assay, from the lowest: compounds 2, 3 and 1 (each within the scatter of the next).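

On the carbonyl carbon, 6-chloropyridin-3-yl has now been compared with both 4-methylphenyl and 4-chlorophenyl, and in this assay neither exchange leaves the scatter: the record shows a 1.5-fold lower number from compound 1 to compound 3 (0.18 log units; within the scatter), and a 1.1-fold higher number from compound 2 to compound 3 (0.05 log units; within the scatter). Among the compounds shown here, the second step is the first pair to address the added ring nitrogen, which here comes with no change that can be told from the scatter while the chloro group stays in place. Nothing available explains why these three groups read alike.

From the compounds shown here alone, whether any group on this carbonyl carbon can move the number beyond the scatter remains open, as all three compounds carry a single six-membered aromatic ring with one substituent. A ring bearing an amine or a carboxylic acid, or a longer alkyl chain in place of the ring, would put that question to the test.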